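This account rests on a few compounds, and the source may have more. Where it says the series, first, only, none or still open, it means among the compounds named here.

Measured compounds:
compound 1, `Cc1cc(=O)n(-c2cccc(F)c2)nc1C(=O)Nc1ccc(Oc2ncnc3[nH]ccc23)cc1`, 34800 nM
compound 2, `Cc1cc(=O)n(-c2ccc(Br)cc2F)nc1C(=O)Nc1ccc(Oc2ncnc3[nH]ccc23)cc1`, 3770 nM
compound 3, `Cc1cc(=O)n(-c2ccc(Br)cc2F)nc1C(=O)Nc1ccc(Oc2ncnc3c2ccn3C)c(F)c1`, 14400 nM

All three were tested in a functional assay on A549 cells (Homo sapiens) for cytotoxicity, read by MTT assay, with a stated time of 72 h; a lower number here means a stronger inhibitor, a higher number a weaker inhibitor. Compound 2 and compound 1 share one core and differ by a single change, (3-fluorophenyl in place of 4-bromo-2-fluorophenyl on an aromatic nitrogen), which gave a 9.2-fold higher number from compound 2 to compound 1 (0.97 log units; beyond the scatter). Compound 3 has a different core; how it differs from compound 2 is not broken down here. Compound 4, `Cc1cc(=O)n(-c2cccc(F)c2)nc1C(=O)Nc1ccc(Oc2ncnc3c2ccn3C)c(F)c1`, is not yet measured; it differs from compound 3 by 3-fluorophenyl in place of 4-bromo-2-fluorophenyl on an aromatic nitrogen, the same change seen between compound 2 and compound 1, at the same place. Compound 3 already sits at the weaker end of the measured numbers. Because the earlier change gave a 9.2-fold higher number from compound 2 to compound 1 (0.97 log units; beyond the scatter), the step from compound 3 to compound 4 is expected to be of similar size, about a 7.6-fold higher number from compound 3 to compound 4 (0.88 log units; beyond the scatter). Compound 4 is therefore estimated at 110000 nM, between 40000 nM and 300000 nM.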

Compound 4, half-maximal inhibitory concentration: > 60000 nM
Compound 4: no number, only a limit; the forecaster's own chance of this, stated with the estimate: 35%; the middle value lies beyond the limit too.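

In this assay, putting 3-fluorophenyl in place of 4-bromo-2-fluorophenyl on the aromatic nitrogen again weakened the compound, giving an at least 4.1-fold higher number from compound 3 to compound 4 (0.61 log units; beyond the scatter). Compound 4 reads > 60000 nM, which is a limit of the assay and not a number. The direction of the change therefore held on both cores shown, but a matching size is not shown: the same change on two cores in this assay, a 9.2-fold higher number (0.97 log units; beyond the scatter) from compound 2 to compound 1 and an at least 4.1-fold higher number (0.61 log units; beyond the scatter) from compound 3 to compound 4; the limit leaves it open whether they differ

The compounds shown leave open which part of the change matters, the loss of the bromine or the move of the fluorine. Also open, from the compounds shown here alone, is how a group such as an amine or a carboxylic acid would read at this place in this assay.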